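A few compounds are considered here, and "the series" means these few. Any claim that something is new, unique, unknown or untested is made for them only; others in the source may bear on it.

Compound 1 `O=C(N/N=C/c1ccccc1)c1cccnc1Nc1cccc(C(F)(F)F)c1`: 21.2%
Compound 2 `O=C(N/N=C/c1cccc(F)c1)c1cccnc1Nc1cccc(C(F)(F)F)c1`: 37%
Compound 3 `O=C(N/N=C/c1ccc(F)cc1)c1cccnc1Nc1cccc(C(F)(F)F)c1`: 41.3%

In a functional assay on the whole organism (strain Wistar) for inhibition, with Rattus norvegicus as the target, read by paw edema, with a stated time of 3 h, at a dose of 10 mg/kg by the intraperitoneal route (on this read-out higher numbers stand for more inhibition at the one dose given (going by the name of the read-out) and lower numbers for less inhibition), compound 3 holds the highest of the three numbers, but the step of a number 4.3 percentage points higher from compound 2 to compound 3 (within the scatter) is within the scatter, whereas the step of a number 20.1 percentage points higher from compound 1 to compound 3 (beyond the scatter) is beyond it. Compound 4 `O=C(N/N=C/c1cccc(Cl)c1)c1cccnc1Nc1cccc(C(F)(F)F)c1` differs from compound 3 by 3-chlorophenyl in place of 4-fluorophenyl on a carbon with a double bond to nitrogen. Among the compounds with values here, only the step of a number 4.3 percentage points higher from compound 2 to compound 3 (within the scatter) bears on exchanging one fluorophenyl for another, and it was within the scatter; no measured step covers chloro in place of fluoro. A step of about a number 3.3 percentage points lower from compound 3 to compound 4 (within the scatter) is therefore expected, with no direction beyond the scatter. Compound 4 is estimated at 38%, in the range 25% to 51%.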

Compound 4, a percentage reported as inhibition, in the whole organism at one dose (the size of the read-out at that dose, not a potency): 55.2%
Compound 4: the middle estimate sits 17.2 percentage points below what was measured, outside the stated range (above it).
By their numbers in this assay, from the lowest: compound 1; then compounds 2 and 3 (each within the scatter of the next); then compound 4.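

At this position the choice of halogen matters more than the two fluorophenyl groups suggested, since they stayed within the scatter of each other: in this assay, 3-chlorophenyl in place of 4-fluorophenyl gives a number 13.9 percentage points higher from compound 3 to compound 4 (beyond the scatter) and chloro in place of fluoro on an aromatic carbon gives a number 18.2 percentage points higher from compound 2 to compound 4 (beyond the scatter). Chloro in place of hydrogen gives a number 34 percentage points higher from compound 1 to compound 4 (beyond the scatter), the largest step in this set. Nothing measured here explains why chloro and fluoro differ. Still open, from the compounds shown here alone, is how 4-chlorophenyl would compare with 3-chlorophenyl, and whether bromo or methoxy on this ring would read higher or lower.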